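The source may report more compounds than this note shows. Statements on the series, on what has been measured and on what is new or still open speak of the compounds shown alone.

Among the compounds with values here, compound 2, with the structure `CCc1ccc(NC(=O)Nn2c(-c3ccccc3)nc3ccccc3c2=O)cc1`, is the one compound of this set that carries a phenyl group on its shared core, and in a functional assay on the whole organism (strain albino) with Mus musculus as the target, at a dose of 100 mg/kg by the intraperitoneal route (a higher number here means more inhibition at the dose given (going by the name of the read-out), a lower number less inhibition), compound 2 gives 61%. That is the highest of the three numbers, but the gap to compound 3, `CCc1nc2ccccc2c(=O)n1NC(=O)Nc1ccccc1`, which in this assay gives 54%, is within the usual scatter, so the two numbers are level. Within the data shown here, compound 1, `CCc1nc2ccccc2c(=O)n1NC(=O)Nc1ccc([N+](=O)[O-])cc1`, gives 41%, and this is the only value that lies clearly below compound 2.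

Compound 4, `CCOc1ccc(NC(=O)Nn2c(-c3ccccc3)nc3ccccc3c2=O)cc1`, differs from compound 2 in a single place: ethoxy in place of ethyl on an aromatic carbon.

Among the measured compounds shown here, the one measured step, a number 13 percentage points higher from compound 1 to compound 3 (beyond the scatter), concerns a different group on the same aryl ring and a different core, so no measured step bears directly on the change from ethyl to ethoxy. Without a matched pair, the expectation is a step of no clear size in this assay, within the scatter, in either direction: the estimated step is a number 4 percentage points lower from compound 2 to compound 4 (within the scatter). The value of compound 4 is therefore expected at 57%, within a range from 40% to 74%.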

Compound 4, a percentage reported as inhibition, in the whole organism at one dose (the size of the read-out at that dose, not a potency): 53%
The estimate for compound 4 lay 4 percentage points above the measured number; low and high end bracket the measured number.
By their numbers in this assay, from the lowest: compound 1; then compounds 4, 3 and 2 (each within the scatter of the next).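

In this assay, within the data shown here, the change from ethyl to ethoxy gives a number 8 percentage points lower from compound 2 to compound 4 (within the scatter), and this is the first matched pair to test this position directly. On an aromatic carbon para to a large group, the ring can therefore carry the added oxygen, with its one hydrogen-bond acceptor, without a shift that can be told from the scatter in this whole-animal read-out. Nothing available explains why the two groups read alike.

A single pair cannot show whether an amine, a carboxylic acid or a longer chain such as butoxy at the same place would move the number beyond the scatter. It also leaves open whether ethoxy in place of ethyl would read the same on the core of compound 3, which carries ethyl where compound 2 carries phenyl.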